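The source may hold more compounds than are shown below. What is called first, only, known or untested is meant among the compounds shown, and "the series" means these compounds.

Measured compounds:
compound 1, `COC(=O)[C@@]1(C)CCC=C2[C@@H]1CC[C@@H](C)[C@]2(C)Cc1c(C)[nH]c2ccc(Br)cc12`, 15000 nM
compound 2, `COC(=O)[C@@]1(C)CCC=C2[C@@H]1CC[C@@H](C)[C@]2(C)Cc1c(C)[nH]c2ccc(Cl)cc12`, 15000 nM
compound 3, `COC(=O)[C@@]1(C)CC[C@@H]2C3=C1CC[C@@H](C)[C@]3(C)Cc1c2[nH]c2c(Br)cccc12`, 26000 nM

Of the compounds shown here, three have been tested in a functional assay on HBL-100 cells (Homo sapiens) for inhibition, read by sulforhodamine B assay, with a stated time of 48 h; on this read-out lower numbers stand for stronger inhibition of growth and higher numbers for weaker inhibition of growth. Compound 1 has the structure `COC(=O)[C@@]1(C)CCC=C2[C@@H]1CC[C@@H](C)[C@]2(C)Cc1c(C)[nH]c2ccc(Br)cc12` and in this assay compound 1 gives 15000 nM. Compound 2, `COC(=O)[C@@]1(C)CCC=C2[C@@H]1CC[C@@H](C)[C@]2(C)Cc1c(C)[nH]c2ccc(Cl)cc12`, differs from compound 1 by chloro in place of bromo on an aromatic carbon, and in this assay compound 2 gives 15000 nM. The step of no change at the digits printed from compound 1 to compound 2 (within the scatter) shows that this exchange left the read-out where it was.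

Compound 3, `COC(=O)[C@@]1(C)CC[C@@H]2C3=C1CC[C@@H](C)[C@]3(C)Cc1c2[nH]c2c(Br)cccc12`, is built on a different core; how the core of compound 3 differs from the core of compound 1 is not broken down here. In this assay compound 3 gives 26000 nM. This value and those of compound 1 and compound 2 lie within the usual scatter of one another, so no order among the three can be read from these numbers.

Compound 4, `COC(=O)[C@@]1(C)CC[C@@H]2C3=C1CC[C@@H](C)[C@]3(C)Cc1c2[nH]c2c(Cl)cccc12`, has not yet been measured. It differs from compound 3 by chloro in place of bromo on an aromatic carbon. Going by the values given here, this is the same kind of change as the one between compound 1 and compound 2, but not the same: in compound 2 the chloro sits on a ring that is part of a fused or bridged system of two rings, meta to a fused ring and para to a fused ring, whereas in compound 4 the ring belongs to a fused or bridged system of five rings and the chloro sits ortho to a fused ring and meta to a fused ring. The change from compound 1 to compound 2 gave no change at the digits printed from compound 1 to compound 2 (within the scatter). For compound 4 a step of about the same size is expected, no change at the digits printed from compound 3 to compound 4 (within the scatter). In this assay compound 4 is therefore estimated at 26000 nM, with a likely range from 13000 nM to 52000 nM.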

Compound 4, concentration for 50% growth inhibition: 16000 nM
Compound 4: the middle estimate sits 1.6-fold (0.21 log units) above what was measured; measured number inside the range.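

In this assay, putting chloro in place of bromo on an aromatic carbon of the system of five rings gives a small step, a 1.6-fold lower number from compound 3 to compound 4 (0.21 log units; within the scatter). Set beside the same exchange on the other core, the two steps agree: the same change on two cores in this assay, no change at the digits printed (within the scatter) from compound 1 to compound 2 and a 1.6-fold lower number (0.21 log units; within the scatter) from compound 3 to compound 4, 1.6-fold (0.21 log units) apart, within the scatter of two such steps. This shows that, on these two cores and in this one assay, the exchange of bromo for chloro carries over as a step too small to read, but it rests on just two pairs and does not show that the two halogens would be interchangeable on another core, at another place on the ring or in another cell line.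

The compounds shown leave open what happens when the halogen on the aromatic ring gives way to plain hydrogen or to a group of another kind, such as methoxy, a nitrile or an amine, since bromo and chloro are the only groups compared there. They also leave open how growth inhibition would respond to a change elsewhere in the molecule, for example a carboxylic acid in place of the methyl ester.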